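The compounds below may be only part of what the source reports. "The series", "measured", "known", "first", "only" and "open" are said of these compounds alone.

Compound 3 (`CCCC/C(=N\C#N)N(C)Cc1ccc(Cl)nc1`) carries a butyl chain, and in a physicochemical assay for lipophilicity, read by HPLC, using the shake flask method (on this read-out lower numbers stand for lower lipophilicity and higher numbers for higher lipophilicity), compound 3 gives 1.87 as its reading. That puts it in the middle of the three measured compounds: compound 1 (`CCC/C(=N\C#N)N(C)Cc1ccc(Cl)nc1`) gives 1.55 as the lowest number and compound 2 (`CCCCC/C(=N\C#N)N(C)Cc1ccc(Cl)nc1`) gives 2.3 as the highest. Compound 4 (`CN(Cc1ccc(Cl)nc1)/C(=N/C#N)c1ccccc1`) has not yet been measured in this assay and differs from compound 3 as follows: phenyl in place of butyl on a carbon with a double bond to nitrogen.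

The measured steps are a number 0.32 log units higher from compound 1 to compound 3 (beyond the scatter) and a number 0.75 log units higher from compound 1 to compound 2 (beyond the scatter) going up and a number 0.43 log units lower from compound 2 to compound 3 (beyond the scatter) going down. All are modest and beyond the scatter. Among these three compounds the longer chain goes with the higher number, and none goes against that. Going by the values given here, all of these steps change only the length of the chain, however, and no measured compound has a ring at this place, so they offer only a loose guide. The rise of a number 0.32 log units higher from compound 1 to compound 3 (beyond the scatter) shows how far a small chain change can move the number, and it suggests a wide range for compound 4 rather than a direction. No step beyond the scatter is expected here. The estimated change is a number 0.08 log units higher from compound 3 to compound 4 (within the scatter) on this evidence. Compound 4 is expected to read 1.95 with an estimated range from 1.55 to 2.35 on this scale.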

Compound 4, partition coefficient: 1.86
For compound 4 the middle estimate is 0.09 log units above the measured one, and the stated range covers the measured number.
By their numbers in this assay, from the lowest: compound 1; then compounds 4 and 3 (each within the scatter of the next); then compound 2.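

In this assay, the first ring at this place, on a carbon with a double bond to nitrogen, gives a number 0.01 log units lower from compound 3 to compound 4 (within the scatter), so phenyl and butyl cannot be told apart here even though phenyl has 6 heavy atoms and butyl has 4. Set against the other two chains, phenyl gives a number 0.44 log units lower from compound 2 to compound 4 (beyond the scatter) where pentyl leaves and a number 0.31 log units higher from compound 1 to compound 4 (beyond the scatter) where propyl leaves, which places the ring inside the span of the chains rather than beyond it and shows that a higher count of heavy atoms at this place need not bring a higher number. Nothing in the data shown explains why the phenyl ring and the butyl chain read alike.

As far as these compounds go, whether this match between ring and chain would hold for a saturated cyclohexyl ring, or for a pyridyl ring with nitrogen in the ring, remains open. Also open, from the compounds shown here alone, is how an amine or a carboxylic acid at this place would shift the reading, and whether a chain longer than pentyl would keep the number climbing.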